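From hydroxymethyl to propyl on the side chain

A few compounds are considered here, and "the series" means these few. Any claim that something is new, unique, unknown or untested is made for them only; others in the source may bear on it.

compound 1 `Cc1ccc(-c2cn(CCCN3C(=O)COc4ccccc43)nn2)cc1` gives 14300 nM
compound 2 `CCCCCCc1cn(CCCN2C(=O)COc3ccccc32)nn1` gives 100 nM
compound 3 `O=C1COc2ccccc2N1CCCn1cc(CO)nn1` gives 7300 nM

All three values come from a functional assay on HeLa cells (Homo sapiens) for antiproliferative activity, read by sulforhodamine B assay, with a stated time of 48 h (on this read-out lower numbers stand for stronger inhibition of growth and higher numbers for weaker inhibition of growth), and are compared here. The step of a 2.0-fold lower number from compound 1 to compound 3 (0.29 log units; within the scatter) leaves those two level, while compound 3 stands far from the hexyl compound. Compound 4 `CCCc1cn(CCCN2C(=O)COc3ccccc32)nn1` differs by ethyl in place of hydroxy on a saturated chain carbon bound to an aromatic carbon in one place: ethyl in place of hydroxy on a saturated chain carbon bound to an aromatic carbon, so hydroxymethyl becomes propyl. Propyl is a shorter chain than hexyl, so only part of a 73-fold higher number from compound 2 to compound 3 (1.86 log units; beyond the scatter) when run in reverse is expected. The step of a 140-fold lower number from compound 1 to compound 2 (2.16 log units; beyond the scatter) starts from a different group and guides less. An estimated 4.9-fold lower number from compound 3 to compound 4 (0.69 log units; beyond the scatter) is expected in this assay for this change. The estimate for compound 4 is 1500 nM and is expected within 350 nM to 6500 nM as its range.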

Compound 4, concentration for 50% growth inhibition: 23200 nM
Estimate against measurement, compound 4: 15-fold (1.19 log units) below; the whole stated range lies below it.
By their numbers in this assay, from the lowest: compound 2; then compounds 3, 1 and 4 (each within the scatter of the next, the first and the last beyond it).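

In this assay, a plain carbon chain alone does not bring strong growth inhibition at this position: ethyl in place of hydroxy gives weaker inhibition (a 3.2-fold higher number from compound 3 to compound 4 (0.50 log units; beyond the scatter)). Shortening hexyl to propyl costs a great deal (a 230-fold higher number from compound 2 to compound 4 (2.37 log units; beyond the scatter)), so among these compounds the low number belongs to hexyl, not to just any chain. Propyl and 4-methylphenyl stand level (a 1.6-fold higher number from compound 1 to compound 4 (0.21 log units; within the scatter)). As far as these compounds go, whether butyl, pentyl or a longer chain such as octyl would match hexyl stays open. Nothing measured here explains why these groups differ.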